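The compounds below may be only part of what the source reports. "The series", "measured", "known", "first", "only" and "open" are said of these compounds alone.

Results so far in an ADME assay on J774.A1 cells (Mus musculus) for cytotoxicity, read by MTT assay, with a stated time of 48 h; on this read-out higher numbers stand for lower toxicity in this test and lower numbers for higher toxicity in this test
Compound 1 (`COC(=O)c1c([N+](=O)[O-])noc1-c1ccccc1`): "not determined" (no result reported)
Compound 2 (`COC(=O)c1c([N+](=O)[O-])noc1-c1ccccc1[N+](=O)[O-]`): "not determined" (no result reported)
Compound 3 (`COC(=O)c1c([N+](=O)[O-])noc1-c1ccccc1Cl`): 80100 nM

Compound 3 is the only one of these with a number. Compound 1 and compound 2 have no result, so there is nothing to rank it against, and nothing yet shows how the value responds to a structural change.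

Compound 4 (`COC(=O)c1c([N+](=O)[O-])noc1-c1ccccc1Br`) is the next to be measured. It differs from compound 3 by a single swap: bromo in place of chloro on an aromatic carbon (bromo in place of chloro on an aromatic carbon, ortho to a large group).

For the measured compounds named here, no measured pair shows what such a swap does in this assay here. Going by the values given here, the only anchor is compound 3 at 80100 nM and the swap is small, so the forecast stays close to that value. The expected move is a 1.1-fold lower number from compound 3 to compound 4 (0.02 log units; within the scatter) and this lies within the usual scatter, so no clear direction is expected. The estimate for compound 4 is 76000 nM with an expected range of 35000 nM to 165000 nM in repeated measurements.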

Compound 4, half-maximal cytotoxic concentration: 34800 nM
Estimate against measurement, compound 4: 2.2-fold (0.34 log units) above; the whole stated range lies above it.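

In this assay, the aromatic carbon ortho to a large group proves sensitive to which halogen it carries: bromo in place of chloro gives a 2.3-fold lower number from compound 3 to compound 4 (0.36 log units; beyond the scatter) and this step is modest but beyond the usual scatter. A lower number stands for higher toxicity in this test, so in this single pair the bromo compound is the more toxic of the two. No measurement shown explains why the two halogens differ.

One pair cannot show whether a fluoro, an iodo, a methoxy or an amine at this place would continue the same direction or break from it. Compound 1 and compound 2 have no number, so the unsubstituted and nitro versions give no reference point for judging either halogen.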